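The source may hold more compounds than are shown below. What is called first, only, known or untested is meant among the compounds shown, and "the series" means these compounds.

This account follows one change within a small set sharing a single core. In an ADME assay on microsomes from liver (Rattus norvegicus) for metabolic stability, with a stated time of 10 min (a lower number here means that less of the compound is left, a higher number that more of the compound is left), compound 1 `c1ccc(Sc2nn3cc(-c4cc5ccccc5o4)nc3s2)cc1` gives "not determined" (no result reported) and so contributes no number. Compound 2 `COc1cc(OCc2cccc(Oc3ccccc3)c2)c2cc(-c3cn4nc(OC)sc4n3)oc2c1` is the only compound with a figure: in this assay compound 2 gives 42%, and since compound 1 lacks a result, compound 2 stands alone, with nothing shown above or below it. Compound 3 `COc1cc(OCc2cccc(OCc3ccccc3)c2)c2cc(-c3cn4nc(OC)sc4n3)oc2c1` differs from compound 2 in one place, (benzyl in place of phenyl on an oxygen on an aromatic ring). No step between two measured compounds is known, so nothing shown tells how far a change of this kind moves the read-out. The step of a number 9 percentage points lower from compound 2 to compound 3 (within the scatter) is expected to be modest and downward, possibly not exceeding the usual scatter. For compound 3 the expected value is 33%, within a range from 15% to 55%.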

Compound 3, percent of the compound remaining: 76%
Compound 3: the middle estimate sits 43 percentage points below what was measured; measured number above the stated range.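

In this assay, placing benzyl in place of phenyl on an oxygen on an aromatic ring gives a number 34 percentage points higher from compound 2 to compound 3 (beyond the scatter). Going by these compounds alone, this is the first measured step at this position, and it shows that this one exchange, phenoxy to benzyloxy, can move the read-out beyond the scatter, even though the counted hydrogen-bond donors, hydrogen-bond acceptors and net charge of the two groups are the same. No measurement shown accounts for the size or direction of this step.

The compounds shown leave open whether a longer chain, such as phenethyl on that oxygen, would carry the read-out further, and how an amine at this place would read. Within the data shown here, with only this single step, they also leave open whether the same exchange would move the read-out similarly on another core.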